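The compounds below may be only part of what the source reports. "The series", "measured", "known", "first", "only" and "open" are said of these compounds alone.

Measured compounds:
- compound 1 `CN1[C@@H]2c3[nH]c4ccccc4c3C[C@H]1[C@H](C#N)N1[C@@H](CNC(=O)c3ccc(Cl)cc3)c3[nH]c4ccccc4c3C[C@@H]21`: in a functional assay on A2780 cells (Homo sapiens) for cytotoxicity, read by MTT assay, with a stated time of 72 h (on this read-out lower numbers stand for stronger inhibition and higher numbers for weaker inhibition), compound 1 gives 230 nM
- compound 2 `CN1[C@@H]2c3[nH]c4ccccc4c3C[C@H]1[C@H](C#N)N1[C@@H](CNC(=O)c3cc4ccccc4o3)c3[nH]c4ccccc4c3C[C@@H]21`: compound 2 gives 230 nM
- compound 3 `CN1[C@@H]2c3[nH]c4ccccc4c3C[C@H]1[C@H](C#N)N1[C@@H](CNC(=O)/C=C/c3cccc(C(F)(F)F)c3)c3[nH]c4ccccc4c3C[C@@H]21`: compound 3 gives only a limit, > 10000 nM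

Compound 3 stands at the limit of > 10000 nM in this assay, at which 1 of the 3 values shown sits, so no number is known for it, only that it sits at that limit. The two measured steps into compound 3 are both large: an at least 43-fold higher number from compound 1 to compound 3 (1.63 log units; beyond the scatter), and an at least 43-fold higher number from compound 2 to compound 3 (1.63 log units; beyond the scatter); in contrast no change at the digits printed from compound 1 to compound 2 (within the scatter). Compound 4 `COc1ccc(/C=C/C(=O)NC[C@H]2c3[nH]c4ccccc4c3C[C@H]3[C@H]4c5[nH]c6ccccc6c5C[C@@H]([C@H](C#N)N23)N4C)cc1` keeps the ethenyl-linked arrangement of compound 3 and differs only at the outer ring: 4-methoxyphenyl in place of 3-(trifluoromethyl)phenyl on a double-bonded chain carbon bound to a double-bonded chain carbon. Going by the values given here, no measured step varies the aryl within that ethenyl arrangement, so the only guidance is that both measured changes into that arrangement reached the limit. The change is therefore expected to give no step beyond the scatter, with compound 4 remaining at the limit, a step that the limit leaves unreadable from compound 3 to compound 4. Compound 4 is estimated at 15000 nM in this assay, within 3000 nM to 60000 nM, most likely reported again as a limit.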

Compound 4, half-maximal inhibitory concentration: 860 nM
Beside the measured number, compound 4's estimate is 17-fold (1.24 log units) above it, and the stated range ends above it.
By their numbers in this assay, from the lowest: compounds 1 and 2 (each within the scatter of the next); then compound 4. At a limit, above all of these: compound 3.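

In this assay, the ethenyl-linked arrangement does not by itself abolish activity: the outer ring matters, with an at least 11-fold lower number from compound 3 to compound 4 (1.06 log units; beyond the scatter) when 4-methoxyphenyl replaces 3-(trifluoromethyl)phenyl on a double-bonded chain carbon bound to a double-bonded chain carbon. The value for compound 3 is a limit and not a number, so that step gives only a minimum size: the limit of > 10000 nM in this assay, at which 1 of the 4 values shown sits. On the carbonyl carbon, 2-(4-methoxyphenyl)ethenyl still gives a modest loss against the two directly attached aryl groups, with a 3.7-fold higher number from compound 1 to compound 4 (0.57 log units; beyond the scatter) and a 3.7-fold higher number from compound 2 to compound 4 (0.57 log units; beyond the scatter).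

The compounds shown do not separate the departure of the 3-(trifluoromethyl) group from the arrival of the 4-methoxy group. From the compounds shown here alone, how a dimethylamino group or a carboxylic acid on the outer ring of the ethenyl arrangement would read remains open.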